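The compounds below may be only part of what the source reports. "The series", "measured", "known", "first", "only" and "open" are said of these compounds alone.

Compound 1, `O=[N+]([O-])c1c[nH]c(-c2nnc(-c3ccc[nH]3)o2)c1`, is a small molecule carrying a nitro group, and the first question asked of it here is not potency against a target but how harmful it is to healthy cells. In an ADME assay on Vero cells (Chlorocebus sabaeus) for cytotoxicity, read by MTT assay, with a stated time of 72 h (a lower number here means a stronger inhibitor, a higher number a weaker inhibitor), compound 1 gives 227000 nM. A second compound from the same series, compound 2, `Cn1cc([N+](=O)[O-])cc1-c1nnc(Cc2ccccc2F)o1`, gives in this assay a value of 245000 nM. Compound 1 has the lower of these two numbers, but the two values lie within the usual scatter of each other, so no difference in cytotoxicity between compound 1 and compound 2 can be claimed.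

Compound 3, `O=[N+]([O-])c1c[nH]c(-c2nnc(-c3ccco3)o2)c1`, has not yet been measured. It differs from compound 1 in one place: furan-2-yl in place of 1H-pyrrol-2-yl on an aromatic carbon. The group that leaves carries one hydrogen-bond donor, the group that enters one hydrogen-bond acceptor, with the count of heavy atoms unchanged.

Going by the values given here, no measured pair that differs only in this way is available. With both measured compounds close together, the step is expected to be a 1.1-fold higher number from compound 1 to compound 3 (0.02 log units; within the scatter), that is, nothing beyond the scatter. Compound 3 is therefore estimated at 240000 nM, within a range of 110000 nM to 520000 nM.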

Compound 3, half-maximal inhibitory concentration: 370000 nM
Compound 3: middle estimate off by 1.5-fold (0.19 log units), on the low side; measured number inside the range.
By their numbers in this assay, from the lowest: compounds 1, 2 and 3 (each within the scatter of the next).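

At this position, the aromatic carbon of the five-membered ring with 2 nitrogen and 1 oxygen, furan-2-yl in place of 1H-pyrrol-2-yl gives a 1.6-fold higher number from compound 1 to compound 3 (0.21 log units; within the scatter) in this assay. This is the only comparison shown between compounds that differ in one place, and it means that trading the hydrogen-bond donor of the leaving ring for the hydrogen-bond acceptor of the entering ring, with the same count of heavy atoms, produces no difference that can be claimed in this read-out. No independent measurement is available that would help to interpret this result.

The compounds shown leave open whether a group of a different kind at this position, such as an amine, a carboxylic acid or a longer alkyl chain, would move the number beyond the scatter. They also leave open whether furan-2-yl and 1H-pyrrol-2-yl would stay this close on a different core, or in a measurement other than this assay.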